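Swapping the Phenyl Substituent: Estimating Compound 4

This account rests on a few compounds, and the source may have more. Where it says the series, first, only, none or still open, it means among the compounds named here.

In a functional assay on A549 cells (Homo sapiens) for inhibition, read by MTT assay, with a stated time of 72 h (a lower number here means a stronger inhibitor, a higher number a weaker inhibitor), three compounds have been measured so far:
Compound 1 `O=C(Nc1ccc(Oc2ccnc3[nH]ccc23)cc1)c1cn(-c2ccccc2)c2ccccc2c1=O` gives 1030 nM.
Compound 2 `O=C(Nc1ccc(Oc2ccnc3[nH]ccc23)cc1)c1cn(-c2ccc(Cl)cc2)c2ccccc2c1=O` gives 650 nM.
Compound 3 `O=C(Nc1ccc(Oc2ccnc3[nH]ccc23)cc1)c1cn(-c2ccc(Br)cc2)c2ccccc2c1=O` gives 450 nM.

Compound 3 gives the lowest of the three numbers, but only its gap to compound 1 is beyond the scatter: a 2.3-fold lower number from compound 1 to compound 3 (0.36 log units; beyond the scatter), whereas a 1.4-fold lower number from compound 2 to compound 3 (0.16 log units; within the scatter). Compound 4 `O=C(Nc1ccc(Oc2ccnc3[nH]ccc23)cc1)c1cn(-c2ccc(C(F)(F)F)cc2Cl)c2ccccc2c1=O` differs from compound 3 by 2-chloro-4-(trifluoromethyl)phenyl in place of 4-bromophenyl on an aromatic nitrogen. The measured steps each change a single substituent on that phenyl ring and were small: a 1.6-fold lower number from compound 1 to compound 2 (0.20 log units; within the scatter), a 2.3-fold lower number from compound 1 to compound 3 (0.36 log units; beyond the scatter). Within the data shown here, no measured step covers a trifluoromethyl or a second chloro, so the expectation rests only on how small these substituent changes have been. Compound 4 is therefore expected to give about 400 nM (range 150 nM to 1200 nM), which means an expected step of a 1.1-fold lower number from compound 3 to compound 4 (0.05 log units; within the scatter).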

Compound 4, half-maximal inhibitory concentration: 2350 nM
The estimate for compound 4 lay 5.9-fold (0.77 log units) below the measured number; measured number above the stated range.
By their numbers in this assay, from the lowest: compounds 3, 2 and 1 (each within the scatter of the next, the first and the last beyond it); then compound 4.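

In this assay this position can also move the number up: the step to 2-chloro-4-(trifluoromethyl)phenyl is a 5.2-fold higher number from compound 3 to compound 4 (0.72 log units; beyond the scatter) and, from the chlorinated analogue, a 3.6-fold higher number from compound 2 to compound 4 (0.56 log units; beyond the scatter) in the same direction. Even the unsubstituted phenyl gives a lower number, with a 2.3-fold higher number from compound 1 to compound 4 (0.36 log units; beyond the scatter), whereas neither single halogen raised it. No measurement available here explains this rise.

As far as these compounds go, this group differs in two features at once, so it remains open whether the chloro or the trifluoromethyl carries the rise. From the compounds shown here alone, how an amine or a methoxy group on this phenyl would read also remains open.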